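Swapping Propylamino for Dimethylamino on a Shared Core

The source may hold more compounds than are shown below. What is called first, only, known or untested is meant among the compounds shown, and "the series" means these compounds.

Of the compounds shown here, three built on one core have been measured in a functional assay on SW480 cells (Homo sapiens) for inhibition, read by luminescence and resazurin assay, with a stated time of 3 days; on this read-out higher numbers stand for weaker inhibition and lower numbers for stronger inhibition. Compound 1 `CCCNc1nc(NCc2ccc(C(=O)Nc3ccc(F)cc3)cc2)c2cc(C)ccc2n1` gives 1300 nM. Compound 2 `CCCNc1nc(NCc2ccc(NC(=O)c3ccc(F)cc3)cc2)c2ccccc2n1` gives 2000 nM in this assay. Compound 3 `CCCNc1nc(NCc2ccc(C(=O)Nc3ccc(F)cc3)cc2)c2ccccc2n1` gives 1600 nM in this assay, the second highest of the three numbers; its nearest neighbour is compound 1 and its furthest is compound 2, and both gaps lie within the scatter. The two measured steps are a 1.2-fold higher number from compound 1 to compound 3 (0.09 log units; within the scatter) and a 1.3-fold lower number from compound 2 to compound 3 (0.10 log units; within the scatter), each within the scatter.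

Compound 4 `CN(C)c1nc(NCc2ccc(C(=O)Nc3ccc(F)cc3)cc2)c2ccccc2n1` has not yet been measured. It differs from compound 3 in one place: dimethylamino in place of propylamino on an aromatic carbon. Neither measured step touches this position. Among the measured compounds shown here, the step from compound 1 and the step from compound 2 alter other parts of the molecule, and both stayed within the scatter, so they offer no direct precedent for the exchange of propylamino for dimethylamino. For the measured compounds named here, with no step at this position to lean on, and with the three known numbers all lying within the scatter of one another, a change beyond the scatter is not expected in either direction for compound 4 in this assay, the estimated step being a 1.3-fold higher number from compound 3 to compound 4 (0.10 log units; within the scatter). Compound 4 is expected to give about 2000 nM in this assay, within a range from 800 nM to 5000 nM.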

Compound 4, half-maximal inhibitory concentration: 2600 nM
For compound 4 the middle estimate is 1.3-fold (0.11 log units) below the measured one; measured number inside the range.
By their numbers in this assay, from the lowest: compounds 1, 3, 2 and 4 (each within the scatter of the next).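

Among the compounds shown here, at the place between two ring nitrogen atoms, the first reading in this assay is a 1.6-fold higher number from compound 3 to compound 4 (0.21 log units; within the scatter). For the compounds shown here, this position had not been probed by the earlier steps, and the exchange shows that replacing propylamino (4 heavy atoms, 1 hydrogen-bond donor) with dimethylamino (3 heavy atoms, 0 hydrogen-bond donors) does not move the number beyond the scatter, so this pair gives no sign that the donor counted on propylamino matters in this read-out. No measurement shown here offers an explanation for this outcome, whether for the size of the step or for its direction.

The compounds shown leave open whether a longer chain such as butylamino, a cyclic amine such as morpholine or a plain amino group at this place would give a step beyond the scatter. They also leave open whether dimethylamino would behave the same way with the methyl group of compound 1 on the core, or with the reversed amide of compound 2.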